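Swapping a thiophene methyl arm for an indazole

The source may hold more compounds than are shown below. What is called first, only, known or untested is meant among the compounds shown, and "the series" means these compounds.

Measured so far:
- compound 1, `NS(=O)(=O)OC[C@@H]1C[C@@H](n2ncc3c(N[C@H]4CCc5ccccc54)ccnc32)C[C@@H]1O`: > 10000 nM
- compound 2, `NS(=O)(=O)OC[C@@H]1C[C@@H](Nc2ncnc(N[C@H]3CCc4ccccc43)c2F)C[C@@H]1O`: 219 nM
- compound 3, `NS(=O)(=O)OC[C@@H]1C[C@@H](n2nnc3c(NCc4cccs4)ncnc32)C[C@@H]1O`: 15.9 nM

All three share the same sulfamate-bearing cyclopentane core and were tested in an assay on a protein complex for inhibition of NEDD8 activating enzyme (Homo sapiens), read by HTRF, with a stated time of 2 h, in the presence of a further agent that is not named here; on this read-out lower numbers stand for stronger inhibition and higher numbers for weaker inhibition. The value for compound 1 is a limit of the assay, not a number; it sits at the limit of > 10000 nM in this assay, at which 1 of the 3 values shown sits. Compound 2 gives 219 nM and compound 3 gives 15.9 nM, so compound 3 stands at the lowest number of the two that were read, and its gap to compound 2 is beyond the usual scatter.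

Compound 4, `NS(=O)(=O)OC[C@@H]1C[C@@H](n2nnc3c(Nc4n[nH]c5ccccc45)ncnc32)C[C@@H]1O`, has not yet been tested. It differs from compound 3 in one place: 1H-indazol-3-yl in place of (thiophen-2-yl)methyl on a nitrogen on an aromatic ring. The amine that links this group to the shared core stays in place; only the group on it changes, and the change also removes the methylene that separated the thiophene from the nitrogen. For the measured compounds named here, no measured pair shows this kind of swap, so the direction of the step is open. A step within the scatter, or a modest move toward weaker inhibition, is expected from compound 3 to compound 4, namely a 2.5-fold higher number from compound 3 to compound 4 (0.40 log units; beyond the scatter). Compound 4 is therefore estimated at 40 nM, with a range from 8 nM to 200 nM.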

Compound 4, half-maximal inhibitory concentration: > 10000 nM
Compound 4: only a limit was reported; the forecaster's own chance of this, stated with the estimate: 5%; middle value at least 250-fold (2.39 log units) away from the limit.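

In this assay, compound 4 gives > 10000 nM, which is a limit of the assay and not a number, and it is not alone in this set: the limit of > 10000 nM in this assay, at which 2 of the 4 values shown sit.

With the group on a nitrogen on an aromatic ring as the only difference, replacing (thiophen-2-yl)methyl with 1H-indazol-3-yl gives an at least 620-fold higher number from compound 3 to compound 4 (2.79 log units; beyond the scatter), a large step well beyond the scatter. This is the first pair shown that differs in one place, and it shows that inhibition depends strongly on the group at this position: an aromatic group here is not enough to keep the value of compound 3, 15.9 nM.

The swap changes several things at once, as it removes the methylene, replaces the thiophene with a larger two-ring group and adds a hydrogen-bond donor, and the compounds shown cannot separate these changes. A benzyl group on the same amine, or a thiophen-2-yl group attached directly to it, would help show whether the lost methylene or the new ring system accounts for the step.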